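From acetyl to isobutyl on a ring nitrogen

The compounds below may be only part of what the source reports. "The series", "measured", "known", "first", "only" and "open" are said of these compounds alone.

Compound 1 `CC(=O)N1CCC(c2ccc3c(c2)oc(=O)n3C(=O)NCCCCc2ccccc2)CC1`: 0.5 h
Compound 2 `CC(C)CNC(=O)n1c(=O)oc2c(C3CCN(C)CC3)cccc21`: 0.667 h

In an ADME assay on a cell-free system (plasma, Mus musculus) for metabolic stability, read by LC-MS, tested at 2 uM (on this read-out lower numbers stand for a shorter-lived compound and higher numbers for a longer-lived compound), compound 1 gives 0.5 h and compound 2 gives 0.667 h, two numbers within the usual scatter of each other. Compound 3 `CC(C)CN1CCC(c2ccc3c(c2)oc(=O)n3C(=O)NCCCCc2ccccc2)CC1` has isobutyl in place of acetyl on an amine nitrogen in a ring. Among the compounds with values here, no measured pair shows this swap, so its effect is unknown. Within the data shown here, the only guide is the closeness of compound 1 at 0.5 h and compound 2 at 0.667 h, so no shift beyond the scatter is expected in this assay. The expected change is a 1.2-fold higher number from compound 1 to compound 3 (0.08 log units; within the scatter). For compound 3 the estimated half-life is 0.6 h, with an expected range from 0.25 h to 1.4 h.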

Compound 3, half-life: 1 h
Compound 3: the middle estimate sits 1.7-fold (0.22 log units) below what was measured; low and high end bracket the measured number.
By their numbers in this assay, from the lowest: compounds 1, 2 and 3 (each within the scatter of the next).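

Isobutyl in place of acetyl on an amine nitrogen in a ring gives a 2.0-fold higher number from compound 1 to compound 3 (0.30 log units; within the scatter) in this assay. This is a direct reading of the swap on one shared core, and it shows that acetyl and isobutyl cannot be told apart at this position in this read-out, even though only acetyl carries a hydrogen-bond acceptor. Nothing at hand explains this reading. Still open, as far as these compounds go, is whether a carboxylic acid, a longer chain or a bare ring amine on this nitrogen would shift the half-life beyond the scatter.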